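The source may hold more compounds than are shown below. What is called first, only, known or untested is meant among the compounds shown, and "the series" means these compounds.

The measured compounds:
Compound 1, `Cc1cccc(Oc2cccc(CN3CCC(n4cc(C)c(=O)[nH]c4=O)CC3)c2)c1`: in an ADME assay on MRC5 cells (Homo sapiens) for cytotoxicity, read by fluorescence and resazurin assay, with a stated time of 3 days (a higher number here means a weaker inhibitor, a lower number a stronger inhibitor), compound 1 gives > 64000 nM, a limit of the assay rather than a number.
Compound 2, `Cc1cn(C2CCN(Cc3cccc(Oc4ccc(Cl)c(Cl)c4)c3)CC2)c(=O)[nH]c1=O`: in this assay compound 2 gives 6100 nM.
Compound 3, `COc1ccc(Oc2cccc(CN3CCC(n4cc(C)c(=O)[nH]c4=O)CC3)c2)cc1`: in this assay compound 3 gives 28000 nM.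

Of the two actual numbers, compound 3 stands highest, and its nearest neighbour is compound 2: a 4.6-fold higher number from compound 2 to compound 3 (0.66 log units; beyond the scatter), from 4-methoxyphenyl in place of 3,4-dichlorophenyl on an oxygen on an aromatic ring. Compound 1 sits at the limit of > 64000 nM in this assay, at which 1 of the 3 values shown sits.

Compound 4, `Cc1cn(C2CCN(Cc3cccc(Oc4ccc(Cl)c(C(F)(F)F)c4)c3)CC2)c(=O)[nH]c1=O`, has not yet been measured. It differs from compound 3 by 4-chloro-3-(trifluoromethyl)phenyl in place of 4-methoxyphenyl on an oxygen on an aromatic ring. For the measured compounds named here, two measured steps bear on this. First, an at least 10-fold lower number from compound 1 to compound 2 (1.02 log units; beyond the scatter), a large drop when 3,4-dichlorophenyl replaced 3-methylphenyl. Second, the reverse, a 4.6-fold higher number from compound 2 to compound 3 (0.66 log units; beyond the scatter), a modest rise when 4-methoxyphenyl replaced 3,4-dichlorophenyl. The entering 4-chloro-3-(trifluoromethyl)phenyl carries a chloro substituent, as the 3,4-dichlorophenyl of compound 2 does, so a drop back toward compound 2 is expected, beyond the scatter. The expected step is a 5.6-fold lower number from compound 3 to compound 4 (0.75 log units; beyond the scatter). Compound 4 is therefore estimated to give 5000 nM, within a range of 1500 nM to 15000 nM.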

Compound 4, half-maximal inhibitory concentration: 5280 nM
The estimate for compound 4 lay 1.1-fold (0.02 log units) below the measured number; measured number inside the range.
By their numbers in this assay, from the lowest: compounds 4 and 2 (each within the scatter of the next); then compound 3. At a limit, above all of these: compound 1.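

Trifluoromethyl in place of chloro on an aromatic carbon gives a 1.2-fold lower number from compound 2 to compound 4 (0.06 log units; within the scatter), so in this assay this position accepts that swap without a change beyond the scatter. The other two steps, a 5.3-fold lower number from compound 3 to compound 4 (0.72 log units; beyond the scatter) and an at least 12-fold lower number from compound 1 to compound 4 (1.08 log units; beyond the scatter), place compound 4 with compound 2: among the four compounds, the two groups carrying a chloro substituent go with the lower numbers, and no compound shown goes against this. Compound 1 stands at a limit of the assay rather than a number, and nothing measured here accounts for these differences.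

As far as these compounds go, whether the chloro substituent itself is needed stays open, since compound 4 keeps it and only its partner changed. So does the effect of an amine or a carboxylic acid on this same aromatic ring.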